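This account rests on a few compounds, and the source may have more. Where it says the series, first, only, none or still open, it means among the compounds named here.

Compound 1, `Cc1ccc(-c2nn(-c3ccc(S(N)(=O)=O)cc3)cc2/C=N\c2ccc(Cl)cc2)cc1`, is the reference point of this small set. In a functional assay on the whole organism (strain Wistar albino) for inhibition, with Rattus norvegicus as the target, read by paw edema, with stated times of 1 h and 2 h, at a dose of 0.32 mmol/kg by the intraperitoneal route (on this read-out higher numbers stand for more inhibition at the one dose given (going by the name of the read-out) and lower numbers for less inhibition), compound 1 gives 69.1%. Compound 2, `COc1ccc(-c2nn(-c3ccc(S(N)(=O)=O)cc3)cc2/C=N\c2ccc(Cl)cc2)cc1`, is built from it by one change, (methoxy in place of methyl on an aromatic carbon), and in this assay compound 2 gives 63%; the step of a number 6.1 percentage points lower from compound 1 to compound 2 (within the scatter) is small. Compound 3, `Cc1ccc(-c2nn(-c3ccc(S(N)(=O)=O)cc3)cc2/C=C\C(=O)c2ccc(Cl)cc2)cc1`, keeps the core of compound 1 but carries a different group on it, (a group of 11 heavy atoms (9 carbon, 1 oxygen, 1 chlorine; one six-membered aromatic ring of carbon only) in place of a group of 9 heavy atoms (7 carbon, 1 nitrogen, 1 chlorine; one six-membered aromatic ring of carbon only), on an aromatic carbon); in this assay compound 3 gives 53.3%, and the step of a number 15.8 percentage points lower from compound 1 to compound 3 (beyond the scatter) is the only one here that clearly stands out. Compound 4, `COc1ccc(-c2nn(-c3ccc(S(N)(=O)=O)cc3)cc2/C=C\C(=O)c2ccc(Cl)cc2)cc1`, has not yet been measured. It is related to compound 3 exactly as compound 2 is related to compound 1: methoxy in place of methyl on an aromatic carbon. Among the compounds with values here, since the places of the two changes are described in the same words, this is the same change made on the other core, and the only guide to its effect is the pair of compound 1 and compound 2. For compound 4 the step of a number 6.3 percentage points lower from compound 3 to compound 4 (within the scatter) is therefore expected to be small, resting on the step of a number 6.1 percentage points lower from compound 1 to compound 2 (within the scatter) seen on the core of compound 1. In this assay compound 4 is expected to give about 47%, most likely between 37% and 57%.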

Compound 4, a percentage reported as inhibition, in the whole organism at one dose (the size of the read-out at that dose, not a potency): 55.6%
Compound 4: middle estimate off by 8.6 percentage points, on the low side; the range from low to high includes it.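

In this assay, within the data shown here, the same exchange of 4-methylphenyl for 4-methoxyphenyl on the core of compound 3 gives a number 2.3 percentage points higher from compound 3 to compound 4 (within the scatter), and this step cannot be told apart from the one seen on the core of compound 1: the same change on two cores in this assay, a number 6.1 percentage points lower (within the scatter) from compound 1 to compound 2 and a number 2.3 percentage points higher (within the scatter) from compound 3 to compound 4, 8.4 percentage points apart, within the scatter of two such steps The exchange of the larger group, read on the methoxy compounds, gives a number 7.4 percentage points lower from compound 2 to compound 4 (within the scatter), and it too cannot be told apart from its counterpart on the methyl compounds, even though only that counterpart lies beyond the scatter: the same change on two cores in this assay, a number 15.8 percentage points lower (beyond the scatter) from compound 1 to compound 3 and a number 7.4 percentage points lower (within the scatter) from compound 2 to compound 4, 8.4 percentage points apart, within the scatter of two such steps This shows that, on these two cores, methoxy in place of methyl leaves the read-out within the scatter both times, which fits the change carrying over; it does not show that the change carries a fixed effect, since neither step is clearly different from no change and the evidence rests on a single pair of cores at one dose.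

The compounds shown leave open what other groups would do at this place, for example a hydroxyl, an amine or a longer chain such as ethoxy. They also leave open whether the sulfonamide could give way to a carboxylic acid without altering the read-out.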